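A few compounds are considered here, and "the series" means these few. Any claim that something is new, unique, unknown or untested is made for them only; others in the source may bear on it.

Working notes on the series. The shared core of compound 1 `Cc1nc(SCC(=O)Nc2nc(-c3ccc(Cl)cc3)cs2)n(Nc2ccccc2)c1C` is the reference point here. In a functional assay on NCI-H522 cells (Homo sapiens) for antiproliferative activity, read by sulforhodamine B assay, with a stated time of 48 h (a lower number here means a stronger inhibitor of growth, a higher number a weaker inhibitor of growth), compound 1 gives 13700 nM, the lowest of the two numbers in hand. Compound 2 `Cc1ccc(Nn2c(SCC(=O)Nc3nc(-c4ccccc4)cs3)nc(C)c2C)cc1` differs from compound 1 at two places at once; in this assay compound 2 gives 86800 nM, and the two values lie well apart, but with two changes between them no single step can be read from that pair. Compound 3 `COc1ccc(Nn2c(SCC(=O)Nc3nc(-c4ccc(Cl)cc4)cs3)nc(C)c2C)cc1` is the next entry and differs from compound 1 by methoxy in place of hydrogen on an aromatic carbon. For the measured compounds named here, no measured pair isolates this change, so its size is not known from the data; compound 2 does not separate the substituent on the anilino ring from the change at the other end. The step of a 1.5-fold higher number from compound 1 to compound 3 (0.16 log units; within the scatter) is expected to be small, within or only slightly beyond the scatter, most likely toward a weaker inhibitor. Compound 3 is expected to give 20000 nM, in a range from 7000 nM to 60000 nM.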

Compound 3, concentration for total growth inhibition: > 100000 nM
Compound 3: a limit, no number (the forecaster's own chance of this, stated with the estimate: 10%); middle value at least 5.0-fold (0.69 log units) away from the limit.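

Methoxy in place of hydrogen on an aromatic carbon, para to a large group, gives an at least 7.2-fold higher number from compound 1 to compound 3 (0.86 log units; beyond the scatter) in this assay, the first single change in the series that can be read. Going by these compounds, the value of compound 3, > 100000 nM, is a limit of the assay and not a number, so the step is a minimum and its full size is unknown: the limit of > 100000 nM in this assay, at which 1 of the 3 values shown sits. On the core of compound 1, this position therefore responds strongly to this one group.

On these data alone, whether a hydroxy group, an amine or fluorine at the same place would give a similar step remains open. Compound 2 differs from compound 1 at two places at once, so neither of those changes can be read on its own.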